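Chloro in place of hydroxy in compound 3

A few compounds are considered here, and "the series" means these few. Any claim that something is new, unique, unknown or untested is made for them only; others in the source may bear on it.

For the measured compounds named here, compound 2 `O=C(/C=C/c1cc2ccccc2[nH]c1=O)c1ccc(O)cc1` gives 2380 nM in a functional assay on CCRF-CEM cells (Homo sapiens) for cytotoxicity, read by sulforhodamine B assay, with a stated time of 24 h (a lower number here means a stronger inhibitor of growth, a higher number a weaker inhibitor of growth), the lowest of the two numbers so far, though compound 1 `COc1ccc(C(=O)/C=C/c2cc3ccccc3[nH]c2=O)cc1`, which gives 4040 nM, stands within the scatter of it. Going by the values given here, the only measured step is a 1.7-fold lower number from compound 1 to compound 2 (0.23 log units; within the scatter), a change at the same place but of a different group. Compound 3 `O=C(/C=C/c1cc2ccccc2[nH]c1=O)c1ccc(Cl)cc1` carries chloro in place of hydroxy on an aromatic carbon. Among the compounds with values here, with no measured step exchanging hydroxy for chloro, this assay is expected to move little: a 1.2-fold lower number from compound 2 to compound 3 (0.08 log units; within the scatter). Compound 3 is estimated at 2000 nM, between 700 nM and 6000 nM.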

Compound 3, concentration for 50% growth inhibition: 3500 nM
Beside the measured number, compound 3's estimate is 1.8-fold (0.24 log units) below it; the measured number falls inside the stated range.
By their numbers in this assay, from the lowest: compounds 2, 3 and 1 (each within the scatter of the next).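

In this assay the step to chloro reads a 1.5-fold higher number from compound 2 to compound 3 (0.17 log units; within the scatter) from the hydroxy side and a 1.2-fold lower number from compound 1 to compound 3 (0.06 log units; within the scatter) from the methoxy side, so all three groups at this position now stand within the scatter of one another. Chloro counts no hydrogen-bond donor or acceptor, yet replacing hydroxy, which counts one of each, moves the number by no more than the scatter. No measurement here speaks to the reason for this. Going by these compounds, whether an amine, a carboxylic acid or a longer chain at this position would stay within that scatter remains open.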